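Amide versus urea on the shared core: compound 3

The source may report more compounds than this note shows. Statements on the series, on what has been measured and on what is new or still open speak of the compounds shown alone.

Measured so far:
compound 1 `COc1cc(Cl)cc(-c2nn(-c3cccc(NC(=O)c4ccc(Cl)c(Cl)c4)c3)cc2-c2ccncc2)c1`, 80.1%
compound 2 `COc1cc(Cl)cc(-c2nn(-c3cccc(NC(=O)Nc4ccc(Cl)c(Cl)c4)c3)cc2-c2ccncc2)c1`, 14.2%

Compound 2 holds the lowest number of the two in a functional assay on SK-OV-3 cells (Homo sapiens) for inhibition, read by sulforhodamine B assay, with a stated time of 48 h, tested at 10 uM; a higher number here means a weaker effect of the compound at the concentration tested, a lower number a stronger effect; its nearest neighbour is compound 1, which lies higher by the step of a number 65.9 percentage points lower from compound 1 to compound 2 (beyond the scatter), a difference well beyond the scatter.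

Compound 3 `COc1cc(Cl)cc(-c2nn(-c3cccc(NC(=O)c4cccc(C(F)(F)F)c4)c3)cc2-c2ccncc2)c1` is not yet measured. It differs from compound 2 as follows: 3-(trifluoromethyl)phenyl in place of (3,4-dichlorophenyl)amino on a carbonyl carbon. The carbonyl carbon thus carries a ring directly again, as in compound 1, though with a different ring.

Among the measured compounds shown here, the one measured step that bears on this is a number 65.9 percentage points lower from compound 1 to compound 2 (beyond the scatter), where the urea form gave the much lower number. Compound 3 undoes that change, so a large rise in this assay is expected, back toward the number of compound 1.

For compound 3 the expected value in this assay is 70%, within 45% to 95%. The expected step is a number 55.8 percentage points higher from compound 2 to compound 3 (beyond the scatter).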

Compound 3, a percentage reported as activity, at one concentration (the size of the read-out at that concentration, not a potency): 81.6%
Beside the measured number, compound 3's estimate is 11.6 percentage points below it; the measured number falls inside the stated range.
By their numbers in this assay, from the lowest: compound 2; then compounds 1 and 3 (each within the scatter of the next).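

In this assay, the step of a number 1.5 percentage points higher from compound 1 to compound 3 (within the scatter) shows that the high number does not belong to one ring alone: with a ring directly on the carbonyl carbon, 3-(trifluoromethyl)phenyl and 3,4-dichlorophenyl cannot be told apart. The step of a number 67.4 percentage points higher from compound 2 to compound 3 (beyond the scatter) gives a second large difference from the urea form, so among the three compounds only (3,4-dichlorophenyl)amino on this carbonyl carbon gives the low number, and neither ring-bearing amide goes against this. No measurement is available that explains this difference.

As far as these compounds go, the step from compound 2 to compound 3 changes the ring substituents together with the link, so it remains open whether (3-(trifluoromethyl)phenyl)amino on this carbonyl carbon would match (3,4-dichlorophenyl)amino. Also open, from the compounds shown here alone, is how a benzylamino group, with a methylene carbon between the nitrogen and the ring, would behave in this assay.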